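The source may hold more compounds than are shown below. What is called first, only, known or untested is meant among the compounds shown, and "the series" means these compounds.

In a functional assay on HeLa cells (Homo sapiens) for inhibition, read by MTT assay, with a stated time of 24 h (a lower number here means a stronger inhibitor, a higher number a weaker inhibitor), compound 1 `COc1ccc(NC(=O)Cn2c(=O)c(/C=C\c3ccncc3)nc3ccccc32)cc1OC` gives only a limit, > 100000 nM. Compound 2 `O=C(COc1nc2ccccc2nc1/C=C\c1ccncc1)Nc1ccc(Cl)cc1` likewise reaches only a limit, > 100000 nM. Compound 3 `Cc1ccc(C(=O)Nc2ccc(Cn3c(=O)c(C)nc4ccccc43)cc2)cc1` also returns only a limit, > 100000 nM. Compound 3 therefore stands where the other two stand, at the limit of > 100000 nM in this assay, at which 3 of the 3 values shown sit; no compound shown here yields a number. Compound 4 `Cc1nc2ccccc2n(Cc2ccc(NC(=O)c3ccc(Cl)cc3)cc2)c1=O` differs from compound 3 by chloro in place of methyl on an aromatic carbon. Within the data shown here, no measured step of this kind is available. Compound 4 is expected to move by a number no higher from compound 3 to compound 4 (the limit leaves the size open), no more than the scatter and in no clear direction. Compound 4 is thus estimated to give 100000 nM in this assay, between 30000 nM and 300000 nM, with a limit again the likelier report.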

Compound 4, half-maximal inhibitory concentration: > 100000 nM
Compound 4: only a limit was reported; the forecaster's own chance of this, stated with the estimate: 80%; the middle value lies on the limit itself.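

In this assay, among these compounds, compound 3 and compound 4 both report only a limit, so no step between them can be read: the limit of > 100000 nM in this assay, at which 4 of the 4 values shown sit. The compounds shown leave open how strongly any of them inhibits, and whether chloro in place of methyl matters at all.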